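The compounds below may be only part of what the source reports. "The series", "measured", "known", "first", "only" and "open" are said of these compounds alone.

Measured compounds:
Compound 1 `Cc1nc2c3ccccc3ccc2c2nc3c(ccc4ccccc43)c(-c3ccccc3S)c12` gives 89 ug/mL in a functional assay, read by spectrophotometry, with a stated time of 30 min; on this read-out lower numbers stand for stronger inhibition and higher numbers for weaker inhibition.
Compound 2 `Cc1ccc(-c2c3ccc4ccccc4c3nc3c2c(C)nc2c4ccccc4ccc32)cc1` gives 123 ug/mL in this assay.

For the measured compounds named here, compound 2 stands as the higher of the two numbers so far, but the only measured step, a 1.4-fold higher number from compound 1 to compound 2 (0.14 log units; within the scatter), lies within the scatter, so the two compounds cannot be told apart on this assay.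

Compound 3 `Cc1nc2c3ccccc3ccc2c2nc3c(ccc4ccccc43)c(-c3cc(O)nc4ccccc34)c12` is the next compound. It differs from compound 2 in one place: 2-hydroxyquinolin-4-yl in place of 4-methylphenyl on an aromatic carbon. Going by the values given here, no measured step involves a 2-hydroxyquinolin-4-yl group at this position; the single step known, from a 2-sulfanylphenyl to a 4-methylphenyl group, was within the scatter, so the data give no sign that this position is sensitive to what sits on it. The change to compound 3 is larger in kind than that step, and the expectation is therefore cautious: the number for compound 3 is expected to fall close to that of compound 2, with a 1.2-fold lower number from compound 2 to compound 3 (0.09 log units; within the scatter) meant as no step beyond the scatter. The estimate for compound 3 in this assay is 100 ug/mL, within a range from 40 ug/mL to 300 ug/mL.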

Compound 3, half-maximal inhibitory concentration: 92.1 ug/mL
Estimate against measurement, compound 3: 1.1-fold (0.04 log units) above; low and high end bracket the measured number.
By their numbers in this assay, from the lowest: compounds 1, 3 and 2 (each within the scatter of the next).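

In this assay the aromatic carbon opposite the ring nitrogen takes 2-hydroxyquinolin-4-yl in place of 4-methylphenyl with no change that can be read (a 1.3-fold lower number from compound 2 to compound 3 (0.13 log units; within the scatter)), and the same holds for the exchange with 2-sulfanylphenyl (a 1.0-fold higher number from compound 1 to compound 3 (0.01 log units; within the scatter)). For the compounds shown here, the earlier pair had compared only two groups with a single six-membered aromatic ring, whereas this change brings in a second ring, one with a hetero atom, and compound 3 still cannot be told apart from compound 1 or compound 2, so across these three groups the position shows no sensitivity to what sits on it. The data at hand offer nothing that would account for this lack of response.

Going by these compounds, all three compounds carry an aromatic ring directly on this carbon, so it remains open whether a group of another kind, such as an amine, a carboxylic acid or a longer alkyl chain, would leave the number in the same range or move it beyond the scatter. On these data alone, it also remains open whether a change elsewhere on the shared core, such as at its methyl group, would matter more than any change made here.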